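Hydroxy for (methylsulfanyl)methyl on the chloro-bearing core

The source may hold more compounds than are shown below. What is called first, only, known or untested is meant among the compounds shown, and "the series" means these compounds.

Compound 1 `O=C(CN(c1ncnc2c1ncn2C1CCCCO1)C1CC1)N[C@@H](CO)C(=O)OCc1ccccc1`: 32.2%
Compound 2 `CSCC[C@H](NC(=O)CN(c1nc(Cl)nc2[nH]cnc12)C1CC1)C(=O)OCc1ccccc1`: 44.6%
Compound 3 `CC(C)C[C@H](NC(=O)CN(c1ncnc2c1ncn2C1CCCCO1)C1CC1)C(=O)OCc1ccccc1`: 28.2%

Three esters sharing the cyclopropylamino-acetamide linker have been tested in a functional assay on the whole organism (Tail, strain ICR) with Mus musculus as the target, in the tail flick test, with a stated time of 90 min, at a dose of 25 umol/kg by the oral route; on this read-out lower numbers stand for a weaker effect and higher numbers for a stronger effect at the one dose given. Compound 2 stands highest of the three; its nearest neighbour on the numbers is compound 1, and compound 3 lies furthest away, both differences falling beyond the scatter. Compound 4 `O=C(CN(c1nc(Cl)nc2[nH]cnc12)C1CC1)N[C@@H](CO)C(=O)OCc1ccccc1` keeps the core of compound 2 and changes the amino acid side chain: hydroxy in place of (methylsulfanyl)methyl on a saturated chain carbon, two bonds along the chain from an amide-type nitrogen and a carbonyl carbon.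

Going by the values given here, the one measured step that bears on this is the side-chain exchange on the other core, a number 4 percentage points lower from compound 1 to compound 3 (within the scatter), in which hydroxy and isopropyl give numbers that do not differ beyond the scatter. Among the compounds with values here, no measured pair shows hydroxy against (methylsulfanyl)methyl, and no pair shows the side-chain exchange on the core of compound 2, so the bearing is indirect. Given that the hydroxy-for-isopropyl step was within the scatter, the expectation for compound 4 is a step of a number 7.6 percentage points lower from compound 2 to compound 4 (within the scatter) in this assay, that is a slight lowering that may well fall within the scatter. Compound 4 is therefore expected to give about 37%, with a plausible range from 22% to 52%.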

Compound 4, a percentage reported as activity, at one dose (the size of the read-out at that dose, not a potency): 34.5%
Beside the measured number, compound 4's estimate is 2.5 percentage points above it; low and high end bracket the measured number.
By their numbers in this assay, from the lowest: compounds 3, 1 and 4 (each within the scatter of the next); then compound 2.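

In this assay, the exchange of (methylsulfanyl)methyl for hydroxy gives a number 10.1 percentage points lower from compound 2 to compound 4 (beyond the scatter), a modest step, which shows that on the core of compound 2 the group on this saturated chain carbon, two bonds along the chain from an amide-type nitrogen and a carbonyl carbon, does affect the read-out. The only earlier step at this place, a number 4 percentage points lower from compound 1 to compound 3 (within the scatter), involved another pair of groups on another core and stayed within the scatter, so the position had not yet shown any response. Nothing at hand explains why the read-out responds to this exchange.

The compounds shown leave open whether the difference goes with the sulfur, the length of the chain or the hydroxy itself, a question that a plain propyl chain or a 2-methoxyethyl chain at this place on the core of compound 2 would bear on. They also leave open whether the same exchange gives a step of this size on the core of compound 1, and how a carboxylic acid or an amine at this place would read.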